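Extending a Bromopropoxy Chain with a Selenium-Bearing Group

The compounds below may be only part of what the source reports. "The series", "measured", "known", "first", "only" and "open" are said of these compounds alone.

Within the data shown here, compound 2 `COc1ccc(N(C)c2ccnc(Cl)n2)cc1OCCCBr` gives 862 nM in a functional assay on A549 cells (Homo sapiens) for antiproliferative activity, read by MTT assay, with a stated time of 48 h (on this read-out higher numbers stand for weaker inhibition and lower numbers for stronger inhibition), the highest of the two numbers known, with compound 1 `COc1ccc(N(C)c2ccnc(Cl)n2)cc1Cl` nearest at 621 nM. Among the measured compounds shown here, the one measured step, a 1.4-fold higher number from compound 1 to compound 2 (0.14 log units; within the scatter), lies within the scatter and put 3-bromopropoxy in place of chloro on an aromatic carbon. Compound 3 `COc1ccc(N(C)c2ccnc(Cl)n2)cc1OCCCCC[Se]C#N` differs from compound 2 by a group of 5 heavy atoms (3 carbon, 1 nitrogen, 1 selenium; no ring) in place of one bromine atom, on a saturated chain carbon, three bonds along the chain from an oxygen on an aromatic ring. For the measured compounds named here, no measured step tests a replacement of the bromine on that chain, so the expected step is a 1.2-fold lower number from compound 2 to compound 3 (0.09 log units; within the scatter), close to none beyond the scatter. Compound 3 is estimated at 700 nM, with a range from 250 nM to 2500 nM.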

Compound 3, half-maximal inhibitory concentration: > 10000 nM
Compound 3: only a limit was reported; the forecaster's own chance of this, stated with the estimate: 5%; at least 14-fold (1.15 log units) between middle value and limit.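

Changing the end of this chain can matter a great deal, although the earlier step, a 1.4-fold higher number from compound 1 to compound 2 (0.14 log units; within the scatter), showed no change beyond the scatter. Replacing the bromine with the selenium-bearing group gives an at least 11-fold higher number from compound 2 to compound 3 (1.06 log units; beyond the scatter). For compound 3, this assay gives only a limit, not a number: the limit of > 10000 nM in this assay, at which 1 of the 3 values shown sits.

The compounds shown leave open whether the selenium, the nitrile or the added chain carbons account for this large step. A longer chain still ending in bromine, or one ending in an amine, would help to separate these parts.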